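The source may report more compounds than this note shows. Statements on the series, on what has been measured and on what is new or still open speak of the compounds shown alone.

Of the compounds shown here, three sharing one core have been measured in a functional assay on SH-SY5Y cells (Homo sapiens) for cytotoxicity, read by MTT assay, with stated times of 24 h and 4 h; a lower number here means that less compound is needed, a higher number that more compound is needed for the effect. Compound 1 `COc1cc(CNC(=O)/C=C/c2ccc(O)cc2)ccc1OCc1nc(C)c(C)nc1C` gives 3740 nM in this assay. Compound 2 `COc1ccccc1/C=C/C(=O)NCc1ccc(OCc2nc(C)c(C)nc2C)c(OC)c1` gives 7150 nM in this assay, and compound 3 `COc1ccc(/C=C/C(=O)NCc2ccc(OCc3nc(C)c(C)nc3C)c(OC)c2)cc1` gives 5050 nM in this assay. Compound 3 stands second highest of the three numbers, but the gaps are small: a 1.4-fold higher number from compound 1 to compound 3 (0.13 log units; within the scatter) and a 1.4-fold lower number from compound 2 to compound 3 (0.15 log units; within the scatter), so compound 3 is not set apart from either neighbour.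

Compound 4 `COc1cc(/C=C/C(=O)NCc2ccc(OCc3nc(C)c(C)nc3C)c(OC)c2)cc(OC)c1` has not yet been measured in this assay. It differs from compound 3 in one place: 3,5-dimethoxyphenyl in place of 4-methoxyphenyl on a double-bonded chain carbon bound to a double-bonded chain carbon. The measured steps that touch the same place are a 1.9-fold higher number from compound 1 to compound 2 (0.28 log units; within the scatter) and a 1.4-fold lower number from compound 2 to compound 3 (0.15 log units; within the scatter), both exchanges of the aromatic ring on the double-bonded chain carbon, and a 1.4-fold higher number from compound 1 to compound 3 (0.13 log units; within the scatter), which changes only the substituent on that ring's oxygen. Among the compounds with values here, none of these three steps reached beyond the scatter, and the data hold no step that adds a second methoxy group to that ring.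

On that basis, compound 4 is expected to show no step beyond the scatter in this assay, an expected 1.0-fold lower number from compound 3 to compound 4 (0.00 log units; within the scatter). The estimate for compound 4 in this assay is 5000 nM, with a range from 2300 nM to 11000 nM.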

Compound 4, half-maximal effective concentration: 8660 nM
Compound 4: the middle estimate sits 1.7-fold (0.24 log units) below what was measured; low and high end bracket the measured number.
By their numbers in this assay, from the lowest: compounds 1, 3, 2 and 4 (each within the scatter of the next, the first and the last beyond it).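

In this assay, within the data shown here, the exchange to 3,5-dimethoxyphenyl on a double-bonded chain carbon bound to a double-bonded chain carbon gives the first step at this position that lies beyond the scatter (a 2.3-fold higher number from compound 1 to compound 4 (0.36 log units; beyond the scatter)), a modest one, whereas every step among the earlier compounds stayed within it. The same group does not separate from either methoxy-bearing group that it can replace here: the steps from 4-methoxyphenyl (a 1.7-fold higher number from compound 3 to compound 4 (0.23 log units; within the scatter)) and from 2-methoxyphenyl (a 1.2-fold higher number from compound 2 to compound 4 (0.08 log units; within the scatter)) both lie within the scatter, so only the comparison with 4-hydroxyphenyl shows a separation. No measurement is available that gives a reason for this separation.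

The compounds shown leave open how an amine, a carboxylic acid or a chlorine atom on this aromatic ring would compare with the 4-hydroxyphenyl and 3,5-dimethoxyphenyl groups. They also leave open whether a longer chain between the ring and the amide carbonyl would change the number in this assay, and whether a 3,5-dihydroxyphenyl group would stand with compound 1 or with compound 4.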